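Aldehyde to Alcohol on a Short Side Chain

This account rests on a few compounds, and the source may have more. Where it says the series, first, only, none or still open, it means among the compounds named here.

Of the compounds shown here, two in this small series have been tested in an assay on 32D cells for inhibition of interleukin-15 (Mus musculus), read by resazurin assay, with stated times of 30 min and 2.5 days, in the presence of a further agent that is not named here; on this read-out higher numbers stand for weaker inhibition and lower numbers for stronger inhibition. Compound 1 `CCOC(CCn1c(Cc2nn(C)c(=O)c3ccccc23)nnc1SCC(=O)Nc1ccc(Cl)cc1Cl)OCC` only reached a limit of the assay: in this assay compound 1 gives > 30000 nM, which is a limit and not a number. Among the measured compounds shown here, compound 2 `Cn1nc(Cc2nnc(SCCCCCCCC(=O)Nc3ccc(Cl)cc3Cl)n2CCC=O)c2ccccc2c1=O` supplies the only actual number, giving 2500 nM in this assay. For the measured compounds named here, compound 2 therefore stands alone as the single measured value, with the other result sitting at the limit of > 30000 nM in this assay, at which 1 of the 2 values shown sits, so no measured step between two compounds exists yet in this set.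

Compound 3 `Cn1nc(Cc2nnc(SCCCCCCCC(=O)Nc3ccc(Cl)cc3Cl)n2CCCO)c2ccccc2c1=O` is the next compound to be tested. It differs from compound 2 in one place: hydroxymethyl in place of formyl on a saturated chain carbon, two bonds along the chain from an aromatic nitrogen. The rest of the molecule, including the shared core, is unchanged. Going by the values given here, with no measured step to lean on, the effect is expected to be small, and the estimated step from compound 2 to compound 3 is a 1.2-fold higher number from compound 2 to compound 3 (0.08 log units; within the scatter), which lies within the usual scatter. Compound 3 is thus expected to give about 3000 nM in this assay, within a range from 1000 nM to 10000 nM.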

Compound 3, half-maximal inhibitory concentration: > 30000 nM
Compound 3: no number, only a limit (the forecaster's own chance of this, stated with the estimate: 20%); middle value at least 10-fold (1.00 log units) from the limit.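

Formyl at this position cannot be treated as interchangeable with hydroxymethyl, even though the two groups have the same number of heavy atoms and differ in that only hydroxymethyl carries a hydrogen-bond donor: in this assay, the change gives an at least 12-fold higher number from compound 2 to compound 3 (1.07 log units; beyond the scatter), the first measured step in this set and one that shows this short side chain matters to the result. For compound 3, the result of > 30000 nM is a limit and not a number. Compound 2 now stands out as the only compound shown with an actual number, and it is also the only one shown that carries formyl, while the others sit at the end of the range: the limit of > 30000 nM in this assay, at which 2 of the 3 values shown sit.

A single pair cannot separate the loss of formyl from the arrival of hydroxymethyl, and it cannot show how much weaker compound 3 really is than its limit suggests. An amine, a carboxylic acid or a methyl ether at the end of the same chain remains untested in the compounds shown here, so whether any group other than formyl can hold a measurable value at this position stays open.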